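The compounds below may be only part of what the source reports. "The series", "measured", "known", "first", "only" and "open" are said of these compounds alone.

In an ADME assay on HEK293 cells (Homo sapiens) for antiproliferative activity, read by MTT assay, with a stated time of 24 h (a lower number here means a stronger inhibitor, a higher number a weaker inhibitor), compound 1 `COc1ccc(-c2cc(/C=C/C(=O)c3ccc(Cl)cc3)nc3cc(-c4ccccc4)nn23)cc1OC` gives 44100 nM. Compound 2 `COc1ccc(-c2cc(/C=C/C(=O)c3ccccc3)nc3cc(-c4ccccc4)nn23)cc1OC` gives 51200 nM, and compound 3 `COc1ccc(-c2cc(/C=C/C(=O)c3ccc(C)cc3)nc3cc(-c4ccccc4)nn23)cc1OC` gives 62600 nM. Compound 3 thus gives the highest of these three numbers, yet the step of a 1.2-fold higher number from compound 2 to compound 3 (0.09 log units; within the scatter) and the step of a 1.4-fold higher number from compound 1 to compound 3 (0.15 log units; within the scatter) both lie within the scatter, as does the step of a 1.2-fold higher number from compound 1 to compound 2 (0.06 log units; within the scatter). Across the three measured compounds, swapping chloro, hydrogen and methyl on the aromatic carbon therefore moved nothing beyond the scatter.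

Compound 4 `COc1ccc(-c2cc(C(=O)/C=C/c3ccccc3)nc3cc(-c4ccccc4)nn23)cc1OC` is the next compound. Its difference from compound 3 is (2-phenylethenyl)carbonyl in place of 2-((4-methylphenyl)carbonyl)ethenyl on an aromatic carbon. Part of this change, the loss of the methyl on the aromatic ring, has a close precedent in the step of a 1.2-fold higher number from compound 2 to compound 3 (0.09 log units; within the scatter), which stayed within the scatter. For the measured compounds named here, the other part, the reversal of the carbonyl and ethenyl order within the linker, has no precedent among the measured compounds, so nothing in the data points to a shift in either direction. Compound 4 is therefore expected to give about 55000 nM, within a range from 25000 nM to 120000 nM. The step of a 1.1-fold lower number from compound 3 to compound 4 (0.06 log units; within the scatter) that this estimate implies is expected to stay within the scatter.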

Compound 4, half-maximal inhibitory concentration: 64100 nM
Beside the measured number, compound 4's estimate is 1.2-fold (0.07 log units) below it; measured number inside the range.
By their numbers in this assay, from the lowest: compounds 1, 2, 3 and 4 (each within the scatter of the next).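

For the compounds shown here, the new compound shows that the linker itself can be reversed at this position, on the aromatic carbon opposite the ring nitrogen, without moving the number in this assay beyond the scatter, whereas the earlier compounds had varied only the group on the end ring. The closest comparison is a 1.3-fold higher number from compound 2 to compound 4 (0.10 log units; within the scatter), since the two groups there hold the same atoms with the carbonyl and ethenyl in reversed order, and the steps of a 1.0-fold higher number from compound 3 to compound 4 (0.01 log units; within the scatter) and a 1.5-fold higher number from compound 1 to compound 4 (0.16 log units; within the scatter), which also involve the loss of methyl or chloro, likewise stay within the scatter. No measurement at hand bears on this result or offers a reason for it.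

The compounds shown leave open whether the reversed linker would stay within the scatter with chloro or methyl on its end ring, since only the unsubstituted phenyl appears in that form. They also leave open whether an amine or a carboxylic acid on that ring, or a longer chain in place of the ethenyl, would move the number beyond the scatter at all.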